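The source may report more compounds than this note shows. Statements on the series, on what has been measured and on what is new or still open speak of the compounds shown alone.

Measured compounds:
compound 1, `CC(=O)NCC[C@@H]1C[C@@H](c2ccc(F)c(F)c2)[C@H](NC(=O)c2cc(-c3c(Cl)cnn3C)c(Cl)o2)CN1`: 880 nM
compound 2, `C=CC[C@@H]1C[C@@H](c2ccc(Cl)c(Cl)c2)[C@H](NC(=O)c2cc(-c3c(Cl)cnn3C)c(Cl)o2)CN1`: 990 nM

Both compounds share one core and differ only in the chain on the saturated ring carbon. In a functional assay on OVCAR-8 cells (Homo sapiens) for antiproliferative activity (a higher number here means a weaker inhibitor, a lower number a stronger inhibitor), compound 1 gives 880 nM, and compound 2 gives 990 nM. On the bare numbers compound 2 carries the higher of the two, but the gap to compound 1 lies within the usual scatter, so the two are not separable here. What the pair does show is that the chain at this place can be exchanged without a shift beyond the scatter.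

Compound 3, `Cn1ncc(Cl)c1-c1cc(C(=O)N[C@@H]2CN[C@H](CCN3CCCCC3)C[C@H]2c2ccc(Cl)c(Cl)c2)oc1Cl`, has not yet been measured in this assay. It follows from compound 2 by the change ((piperidin-1-yl)methyl in place of vinyl on a saturated chain carbon bound to a saturated ring carbon). Within the data shown here, no step between measured compounds is available for this kind of exchange; the only guide is the indifference of the numbers of compound 1 and compound 2 to the chain. On that basis a small step is expected, if any, toward a lower number, and it may well stay within the scatter. For compound 3 a value of about 700 nM is estimated, with a range from 200 nM to 2500 nM. This estimate means a step of a 1.4-fold lower number from compound 2 to compound 3 (0.15 log units; within the scatter).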

Compound 3, half-maximal inhibitory concentration: 1660 nM
The estimate for compound 3 lay 2.4-fold (0.38 log units) below the measured number; measured number inside the range.
By their numbers in this assay, from the lowest: compounds 1, 2 and 3 (each within the scatter of the next).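

In this assay, replacing vinyl with (piperidin-1-yl)methyl on a saturated chain carbon bound to a saturated ring carbon gives a 1.7-fold higher number from compound 2 to compound 3 (0.22 log units; within the scatter). Among these compounds, this is the first step at this place that can be read with everything else held constant, and it shows that the chain can grow from 2 heavy atoms to 7 heavy atoms, taking on a six-membered non-aromatic ring and a hydrogen-bond acceptor, without a shift beyond the scatter. No measurement on hand bears on why the number holds across this exchange.

Still open, from the compounds shown here alone, is whether a carboxylic acid or a much longer carbon chain at this place would produce a step beyond the scatter, since a single exchange does not fix the limits of what the position accepts. Also open, going by these compounds, is what the ring nitrogen of the piperidine contributes, a question that cyclohexylmethyl in place of (piperidin-1-yl)methyl on the same core would address directly.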